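The compounds below may be only part of what the source reports. "The series", "measured", "known", "first", "only" and "open" are said of these compounds alone.

Compound 1 `COc1ccc(N(C)c2ccnc(Cl)n2)cc1Cl` gives 1170 nM in a functional assay on HCT-116 cells (Homo sapiens) for antiproliferative activity, read by MTT assay, with a stated time of 48 h; on this read-out higher numbers stand for weaker inhibition and lower numbers for stronger inhibition. Compound 2 `COc1ccc(N(C)c2ccnc(Cl)n2)cc1[N+](=O)[O-]`, carrying the change (nitro in place of chloro on an aromatic carbon), gives 4700 nM in this assay, so that a 4.0-fold higher number from compound 1 to compound 2 (0.60 log units; beyond the scatter). Compound 3 `COc1ccc(N(C)c2cc(C)nc(C)n2)cc1Cl` gives 1190 nM in this assay; the difference between the core of compound 3 and the core of compound 1 is not broken down here, and its value and that of compound 1 lie within the scatter of each other. Compound 4 `COc1ccc(N(C)c2cc(C)nc(C)n2)cc1[N+](=O)[O-]` bears the change nitro in place of chloro on an aromatic carbon on the core of compound 3. This is the same kind of change as from compound 1 to compound 2; around the place, the earlier change sits meta to a group of 9 heavy atoms, the new one meta to a large group. A step of a 3.8-fold higher number from compound 3 to compound 4 (0.58 log units; beyond the scatter) is expected, resting on compound 1 and compound 2, because a 4.0-fold higher number from compound 1 to compound 2 (0.60 log units; beyond the scatter). Compound 4 is therefore estimated at 4500 nM, between 2000 nM and 10000 nM.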

Compound 4, half-maximal inhibitory concentration: 4670 nM
Estimate against measurement, compound 4: 1.0-fold (0.02 log units) below, and the stated range covers the measured number.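

In this assay nitro in place of chloro on an aromatic carbon gives a 3.9-fold higher number from compound 3 to compound 4 (0.59 log units; beyond the scatter) and matches the step on the core of compound 1: the same change on two cores in this assay, a 4.0-fold higher number (0.60 log units; beyond the scatter) from compound 1 to compound 2 and a 3.9-fold higher number (0.59 log units; beyond the scatter) from compound 3 to compound 4, 1.0-fold (0.01 log units) apart, within the scatter of two such steps. Across these two cores, the change therefore carries over at the same size within the scatter. This rests on two pairs only, and it shows neither why the step has this size nor whether it would hold on any other core.

Still open, on these data alone, is how an amine, a nitrile or a carboxylic acid in place of the chloro would compare on either core. Also open, as far as these compounds go, is whether the step survives when the methoxy group gives way to a longer chain such as propoxy.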